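Moving the chlorine on the phenyl ring of a triazole thioether

The compounds below may be only part of what the source reports. "The series", "measured", "known", "first", "only" and "open" are said of these compounds alone.

Measured so far:
compound 1, `COc1ccc(CSc2nnc([C@@H](C)c3ccc4cc(OC)ccc4c3)n2-c2ccc(F)cc2)cc1`: 400000 nM
compound 2, `COc1ccc2cc([C@H](C)c3nnc(SCc4c(C)cc(C)cc4C)n3-c3cccc(Cl)c3)ccc2c1`: 16300 nM
compound 3, `COc1ccc2cc([C@H](C)c3nnc(SCc4c(Cl)cccc4Cl)n3-c3cccc(Cl)c3)ccc2c1`: 165000 nM

Of the compounds shown here, three sharing one core have been tested in a functional assay on PC-3 cells (Homo sapiens) for cytotoxicity, read by MTT assay; on this read-out higher numbers stand for weaker inhibition and lower numbers for stronger inhibition. Compound 3 stands second highest of the three numbers; its nearest neighbour is compound 1, which gives 400000 nM, and its furthest is compound 2, which gives 16300 nM. For the measured compounds named here, the one single-point step that is known, a 10-fold higher number from compound 2 to compound 3 (1.01 log units; beyond the scatter), concerns the benzyl group on the sulfur, not the ring on the nitrogen.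

Compound 4, `COc1ccc2cc([C@H](C)c3nnc(SCc4c(Cl)cccc4Cl)n3-c3ccc(Cl)cc3)ccc2c1`, is not yet measured. It differs from compound 3 in one place: 4-chlorophenyl in place of 3-chlorophenyl on an aromatic nitrogen. Going by the values given here, no measured step in this set changes the aryl ring on the aromatic nitrogen, and the one known step touches a different part of the molecule, so it gives no direct guidance. Compound 1 carries a different ring there, but it also carries a different benzyl group, so its value cannot be read as a step. With nothing pointing either way, the expected step of a 1.1-fold lower number from compound 3 to compound 4 (0.04 log units; within the scatter) is none beyond the scatter. Compound 4 is therefore estimated at 150000 nM in this assay, within a range from 50000 nM to 400000 nM.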

Compound 4, half-maximal inhibitory concentration: 34700 nM
Compound 4: middle estimate off by 4.3-fold (0.64 log units), on the high side; measured number outside the range, below it.
By their numbers in this assay, from the lowest: compound 2; then compound 4; then compound 3; then compound 1.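

In this assay, the position of one chlorine on the ring on the aromatic nitrogen proves to matter: with everything else held fixed and the atom count unchanged, going from 3-chlorophenyl to 4-chlorophenyl gives a 4.8-fold lower number from compound 3 to compound 4 (0.68 log units; beyond the scatter). For the compounds shown here, until now the only readable change lay in the benzyl group on the sulfur, where the step was a 10-fold higher number from compound 2 to compound 3 (1.01 log units; beyond the scatter), so this is the first sign that the number also responds to the ring on the nitrogen, and that a chlorine's place on that ring is enough to shift it beyond the usual scatter. Nothing available explains why the 4-chlorophenyl compound gives the lower number, so the shift stands as an observation only.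

The compounds shown do not tell whether the same move would lower the number with the 2,4,6-trimethylphenyl group of compound 2 on the sulfur side, since compound 2 has no partner that differs from it only in the place of the chlorine. They also leave open what an amine or a carboxylic acid would do in place of the chlorine on this ring.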